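Chloro scan on two tyrphostin-like amide cores

The compounds below may be only part of what the source reports. "The series", "measured", "known", "first", "only" and "open" are said of these compounds alone.

Compound 1 `COc1ccc(CNC(=O)/C(C#N)=C/c2ccco2)cc1` gives, in a functional assay on MIA cells (Homo sapiens) for inhibition, read by MTT assay, with a stated time of 72 h (on this read-out lower numbers stand for stronger inhibition of growth and higher numbers for weaker inhibition of growth), a value of 34000 nM. Compound 2 `COc1ccc(CNC(=O)/C(C#N)=C/c2ccc(Cl)o2)cc1` carries chloro in place of hydrogen on an aromatic carbon, at a place described as next to the ring oxygen of a five-membered aromatic ring with 1 oxygen, and in this assay compound 2 gives 15000 nM; the step is a 2.3-fold lower number from compound 1 to compound 2 (0.36 log units; beyond the scatter). Compound 3 `N#C/C(=C\c1ccccc1)C(=O)NCc1ccc(Cl)c(Cl)c1` rests on a different core, and the difference between the two cores is not broken down here. In this assay compound 3 gives 47000 nM; its value and that of compound 1 lie within the scatter of each other, while its value stands beyond the scatter from that of compound 2.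

Compound 4 `N#C/C(=C\c1ccc(Cl)cc1)C(=O)NCc1ccc(Cl)c(Cl)c1` is derived from compound 3 by chloro in place of hydrogen on an aromatic carbon, the same kind of change as from compound 1 to compound 2, but now on a six-membered aromatic ring of carbon only, para to a large group, rather than on the furan ring. The expectation from compound 3 to compound 4 is a step of a 1.9-fold lower number from compound 3 to compound 4 (0.27 log units; within the scatter), resting on the earlier step of a 2.3-fold lower number from compound 1 to compound 2 (0.36 log units; beyond the scatter). The ring context differs, and the range is therefore set wide. Compound 4 is estimated at 25000 nM, between 11000 nM and 60000 nM.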

Compound 4, concentration for 50% growth inhibition: 31000 nM
Compound 4: the middle estimate sits 1.2-fold (0.09 log units) below what was measured, and the stated range covers the measured number.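

In this assay, phenyl to 4-chlorophenyl gives a 1.5-fold lower number from compound 3 to compound 4 (0.18 log units; within the scatter), so on this core the change cannot be told apart from repeat scatter. Set beside the step on the core of compound 1, the size of the change does not differ measurably between the two cores: the same change on two cores in this assay, a 2.3-fold lower number (0.36 log units; beyond the scatter) from compound 1 to compound 2 and a 1.5-fold lower number (0.18 log units; within the scatter) from compound 3 to compound 4, 1.5-fold (0.17 log units) apart, within the scatter of two such steps. This is compatible with the change carrying across both cores, but it rests on only two pairs, only the step on the core of compound 1 lies beyond the scatter, and a lower number on the core of compound 3 is therefore not shown.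

The compounds shown leave open whether the step would hold on a third core or with chloro on another ring of these molecules. They also leave open how a different group at these places, such as bromo, an amine or a carboxylic acid, would compare with chloro in this assay.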